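Hydroxy on the lactam ring of compound 1

A few compounds are considered here, and "the series" means these few. Any claim that something is new, unique, unknown or untested is made for them only; others in the source may bear on it.

Measured so far:
- compound 1 `CC(C)c1noc(N2CCC(Oc3cc(N4CCc5cc(N6CCCCC6=O)ccc54)ncn3)CC2)n1`: 13 mL.min-1.g-1
- compound 2 `CC(C)c1noc(N2CCC(Oc3cc(N4CCc5cc(C6CCCCC6=O)ccc54)ncn3)CC2)n1`: 141 mL.min-1.g-1
- compound 3 `CCc1cnc(N2CCC(C(C)COC(=O)N3CCc4cc(S(C)(=O)=O)cc(F)c43)CC2)nc1`: 365 mL.min-1.g-1

In an ADME assay on microsomes from liver (Rattus norvegicus) for metabolic stability, read by LC-MS, using NADPH, with a stated time of 30 min, tested at 1 uM (on this read-out lower numbers stand for slow clearance and higher numbers for fast clearance), compound 1 gives 13 mL.min-1.g-1, the lowest of the three numbers; compound 2 sits at 141 mL.min-1.g-1 and compound 3, on a different core, at 365 mL.min-1.g-1, both beyond the scatter from compound 1.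

Going by the values given here, the one step that touches the same position is an 11-fold higher number from compound 1 to compound 2 (1.04 log units; beyond the scatter), a large step; it swaps the whole 2-oxopiperidin-1-yl for 2-oxocyclohexyl and does not bear on a single substituent on the saturated ring.

Compound 4 `CC(C)c1noc(N2CCC(Oc3cc(N4CCc5cc(N6CC(O)CCC6=O)ccc54)ncn3)CC2)n1` differs from compound 1 as follows: hydroxy in place of hydrogen on a saturated ring carbon. Among the compounds with values here, no measured pair shows a hydroxy on a saturated ring carbon, so there is nothing to set the size of the step; the ring and its attachment are kept, which argues against a change of the kind seen between compound 1 and compound 2.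

Compound 4 is therefore expected to stay close to compound 1 in this assay, with a 1.3-fold lower number from compound 1 to compound 4 (0.11 log units; within the scatter) not beyond the scatter. The estimate for compound 4 is 10 mL.min-1.g-1, with a range from 4 mL.min-1.g-1 to 26 mL.min-1.g-1.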

Compound 4, intrinsic clearance in microsomes: 7 mL.min-1.g-1
For compound 4 the middle estimate is 1.4-fold (0.15 log units) above the measured one, and the stated range covers the measured number.
By their numbers in this assay, from the lowest: compounds 4 and 1 (each within the scatter of the next); then compound 2; then compound 3.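

In this assay, going by these compounds alone, the earlier compounds showed only what happens when the whole 2-oxopiperidin-1-yl group is exchanged; compound 4 is the first reading of a small change on that ring itself. Hydroxy in place of hydrogen on a saturated ring carbon, two ring bonds from the ring nitrogen, gives a step that stays within the scatter (a 1.9-fold lower number from compound 1 to compound 4 (0.27 log units; within the scatter)), so on this read-out compound 1 and compound 4 cannot be told apart, while the large gap to the 2-oxocyclohexyl compound remains in place (a 20-fold lower number from compound 2 to compound 4 (1.30 log units; beyond the scatter)). No supporting data accompany this result to explain either step.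

Still open, going by these compounds, is whether this carbon accepts groups other than hydroxy, such as methoxy, an amine or a carboxylic acid, with the number staying within the scatter of compound 1. Also open, on these data alone, is whether a hydroxy on the 2-oxocyclohexyl ring of compound 2 would move its high number, as the step between compound 2 and compound 4 combines that exchange of ring with the hydroxy and cannot separate the two.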